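Aryl hydrazone variation on the shared core

The source may hold more compounds than are shown below. What is called first, only, known or untested is meant among the compounds shown, and "the series" means these compounds.

Among the compounds with values here, compound 3 `CN(C)CCn1cnnc1-c1cc(Oc2ccc(NC(=O)N/N=C/c3ccc(O)c(O)c3)cc2F)ccn1` gives 1930 nM in a functional assay on NCI-H460 cells (Homo sapiens) for cytotoxicity, read by MTT assay, with a stated time of 72 h (on this read-out higher numbers stand for weaker inhibition and lower numbers for stronger inhibition), the highest of the three numbers so far. Compound 1 `CN(C)CCn1cnnc1-c1cc(Oc2ccc(NC(=O)N/N=C/c3ccc(O)c(Br)c3)cc2F)ccn1` gives 430 nM in this assay, and compound 2 `COc1ccc(/C=N/NC(=O)Nc2ccc(Oc3ccnc(-c4nncn4CCN(C)C)c3)c(F)c2)c(OC)c1OC` gives 1790 nM in this assay. The steps among them: a 4.5-fold higher number from compound 1 to compound 3 (0.65 log units; beyond the scatter); a 4.2-fold higher number from compound 1 to compound 2 (0.62 log units; beyond the scatter); a 1.1-fold higher number from compound 2 to compound 3 (0.03 log units; within the scatter).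

Compound 4 `COc1cc(/C=N/NC(=O)Nc2ccc(Oc3ccnc(-c4nncn4CCN(C)C)c3)c(F)c2)ccc1O` differs from compound 3 in one place: methyl in place of hydrogen on an oxygen on an aromatic ring. Read one bond further out, hydroxy becomes methoxy, so 3,4-dihydroxyphenyl becomes 4-hydroxy-3-methoxyphenyl. Within the data shown here, no measured step exchanges hydroxy for methoxy alone. The nearest comparison is a 1.1-fold higher number from compound 2 to compound 3 (0.03 log units; within the scatter), where a methoxy-bearing aryl and a hydroxy-bearing aryl gave numbers within the scatter. The step of a 4.5-fold higher number from compound 1 to compound 3 (0.65 log units; beyond the scatter) concerns bromo, not methyl, and is less informative here. For compound 4 the expected step in this assay is therefore no change beyond the scatter, a 1.1-fold lower number from compound 3 to compound 4 (0.06 log units; within the scatter). The estimate for compound 4 in this assay is 1700 nM, expected to fall between 800 nM and 3600 nM.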

Compound 4, half-maximal inhibitory concentration: 57 nM
Compound 4: the middle estimate sits 30-fold (1.47 log units) above what was measured; the measured number lies below the stated range.
By their numbers in this assay, from the lowest: compound 4; then compound 1; then compounds 2 and 3 (each within the scatter of the next).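

In this assay, adding one methyl to an oxygen of the 3,4-dihydroxyphenyl group gives a 34-fold lower number from compound 3 to compound 4 (1.53 log units; beyond the scatter), so this oxygen is highly sensitive to a small change. The resulting 4-hydroxy-3-methoxyphenyl group also compares well with the other two aryl groups, with a 31-fold lower number from compound 2 to compound 4 (1.50 log units; beyond the scatter) against 2,3,4-trimethoxyphenyl and a 7.5-fold lower number from compound 1 to compound 4 (0.88 log units; beyond the scatter) against the bromo analogue. Counting methoxy or hydroxy groups alone therefore does not sort this series: compound 2 carries only methoxy and compound 3 only hydroxy on the aryl ring, and those two stay within the scatter of each other, whereas compound 4, with one of each, gives the lowest number.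

No available evidence bears on the origin of this step. As far as these compounds go, whether ethoxy, a longer alkoxy chain or an amine in place of this methoxy would keep the low number remains open.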